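Trimethoxyphenyl in Place of Methoxyphenyl on the Shared Core

A few compounds are considered here, and "the series" means these few. Any claim that something is new, unique, unknown or untested is made for them only; others in the source may bear on it.

Three compounds have been measured in a functional assay on the whole organism (strain Swiss albino) with Mus musculus as the target, in the forced swim test, with a stated time of 5 min, at a dose of 0.5 mg/kg by the intraperitoneal route; on this read-out lower numbers stand for less inhibition and higher numbers for more inhibition at the one dose given (going by the name of the read-out):

compound 1 `COc1cc(-c2cc3cc(C4C(C#N)=C(N)OC5=C4C(=O)CCC5)cc(C(C)C)c3oc2=O)cc(OC)c1OC` gives 31.9%
compound 2 `CCC(C)c1cc(C2C(C#N)=C(N)OC3=C2C(=O)CCC3)cc2cc(-c3cc(OC)c(OC)c(OC)c3)c(=O)oc12` gives 56.1%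
compound 3 `COc1ccc(-c2cc3cc(C4C(C#N)=C(N)OC5=C4C(=O)CCC5)cc(C(C)(C)C)c3oc2=O)cc1` gives 30.7%

Compound 3 holds the lowest of the three numbers in this assay. Compound 1 sits nearest to it, and the two lie within the usual scatter of each other, so no order between them can be claimed. Compound 2 lies furthest away, beyond the scatter. Going by the values given here, the only step measured in one place is a number 24.2 percentage points higher from compound 1 to compound 2 (beyond the scatter), a modest rise.

Compound 4 `COc1cc(-c2cc3cc(C4C(C#N)=C(N)OC5=C4C(=O)CCC5)cc(C(C)(C)C)c3oc2=O)cc(OC)c1OC` is the next step, made from compound 3 by 3,4,5-trimethoxyphenyl in place of 4-methoxyphenyl on an aromatic carbon. Among the compounds with values here, no measured step changes this group alone, so nothing directly bears on it. Compound 1 carries the entering group and compound 3 the leaving group, and their values in this assay differ only within the scatter, though they also differ elsewhere on the core. On that basis no step beyond the scatter is expected. Compound 4 is therefore estimated at 33%, in the range 18% to 50%. This estimate implies an expected step of a number 2.3 percentage points higher from compound 3 to compound 4 (within the scatter), within the scatter.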

Compound 4, a percentage reported as inhibition, in the whole organism at one dose (the size of the read-out at that dose, not a potency): 5.33%
Compound 4: the middle estimate sits 27.7 percentage points above what was measured; the measured number lies below the stated range.
By their numbers in this assay, from the lowest: compound 4; then compounds 3 and 1 (each within the scatter of the next); then compound 2.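

In this assay, 3,4,5-trimethoxyphenyl in place of 4-methoxyphenyl gives a number 25.4 percentage points lower from compound 3 to compound 4 (beyond the scatter) with tert-butyl held fixed, so this aromatic carbon is not indifferent to the added methoxy groups. The alkyl group also counts once the trimethoxyphenyl is present: tert-butyl in place of sec-butyl gives a number 50.8 percentage points lower from compound 2 to compound 4 (beyond the scatter) and one more methyl on the carbon bound to the aromatic ring gives a number 26.6 percentage points lower from compound 1 to compound 4 (beyond the scatter) so that, among these three trimethoxyphenyl compounds, the tert-butyl one stands clearly lowest. No measurement on hand explains either change.

Going by these compounds, it remains open whether 3,4,5-trimethoxyphenyl in place of 4-methoxyphenyl would lower the number equally with sec-butyl on the core. Also open, on these data alone, is how a phenyl carrying an amine, or a longer chain in place of the butyl groups, would behave.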